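A Methyl Replaces Fluoro in a Series at the Limit

The source may report more compounds than this note shows. Statements on the series, on what has been measured and on what is new or still open speak of the compounds shown alone.

Three compounds share one core and differ only in the group on the amide-type nitrogen in the ring. Compound 1 `O=C1COc2ccc(-c3cccc(NS(=O)(=O)c4ccc(F)cc4)c3)cc2N1c1ccccc1` carries phenyl there, compound 2 `CC(C)N1C(=O)COc2ccc(-c3cccc(NS(=O)(=O)c4ccc(F)cc4)c3)cc21` carries isopropyl, and compound 3 `O=C1COc2ccc(-c3cccc(NS(=O)(=O)c4ccc(F)cc4)c3)cc2N1c1ccc(F)cc1` carries 4-fluorophenyl. All three were tested in a functional assay on A-375 cells (Homo sapiens) for antiproliferative activity, read by MTT assay, with a stated time of 72 h; on this read-out lower numbers stand for stronger inhibition and higher numbers for weaker inhibition. In this assay compound 1 reaches only the limit > 40000 nM, which is a boundary of the assay and not a number. Compound 2 likewise gives only the limit > 40000 nM. Compound 3 also stops at the limit > 40000 nM. Because every value sits at the limit of > 40000 nM in this assay, at which 3 of the 3 values shown sit, the three steps cannot be read: a step that the two limits leave unreadable from compound 1 to compound 2, a step that the two limits leave unreadable from compound 1 to compound 3 and a step that the two limits leave unreadable from compound 2 to compound 3 all remain unreadable in size. Compound 4 `Cc1ccc(N2C(=O)COc3ccc(-c4cccc(NS(=O)(=O)c5ccc(F)cc5)c4)cc32)cc1` differs from compound 3 in one place: methyl in place of fluoro on an aromatic carbon. Going by the values given here, no measured step speaks directly to this change; the exchanges among phenyl, isopropyl and 4-fluorophenyl all left their compounds at the limit. The expectation is therefore that compound 4 also stays beyond the limit, with the step that the limit leaves unreadable from compound 3 to compound 4 expected to amount to no more than scatter. Compound 4 is estimated at 60000 nM, within the range 20000 nM to 200000 nM.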

Compound 4, half-maximal inhibitory concentration: 36200 nM
The estimate for compound 4 lay 1.7-fold (0.22 log units) above the measured number, within the range that was stated.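

In this assay compound 4, with 4-methylphenyl on the amide-type nitrogen in the ring, gives 36200 nM, the only measured number among the compounds shown. Compound 3 gives > 40000 nM, which is a limit of the assay and not a number, and compounds 1 and 2 stop at that same limit: the limit of > 40000 nM in this assay, at which 3 of the 4 values shown sit. The exchange of fluoro for methyl on an aromatic carbon, para to a large group, gives an at least 1.1-fold lower number from compound 3 to compound 4 (0.04 log units; that floor lies within the scatter), and the other two comparisons give an at least 1.1-fold lower number from compound 2 to compound 4 (0.04 log units; that floor lies within the scatter) and an at least 1.1-fold lower number from compound 1 to compound 4 (0.04 log units; that floor lies within the scatter), so this position can yield a measurable number, but no real gain in activity can be claimed from these floors.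

As far as these compounds go, the steps among compounds 1, 2 and 3 cannot be read, and the true size of the steps to compound 4 stays open, as none of them has more than a floor. Also open, from the compounds shown here alone, is whether an amine or a carboxylic acid in place of the methyl, or a longer chain on the amide-type nitrogen, would bring the number clearly down from that of compound 4.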